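This account rests on a few compounds, and the source may have more. Where it says the series, first, only, none or still open, it means among the compounds named here.

In a functional assay on CHO cells with adenosine receptor A1 (Homo sapiens) as the target, read by cAMP accumulation and immunoassay, with a stated time of 6 min, tested at 1 uM (a higher number here means a weaker effect of the compound at the concentration tested, a lower number a stronger effect), the three measured compounds gave the following read-outs:

Compound 1 `CC(C)N1CCN(Cc2csc(N)c2C(=O)c2ccc(Cl)cc2)CC1`: 7.3%
Compound 2 `Nc1scc(CN2CCN(c3cccc(Cl)c3Cl)CC2)c1C(=O)c1ccc(Cl)cc1`: -57%
Compound 3 `Nc1scc(CN2CCN(c3ccc(Cl)cc3F)CC2)c1C(=O)c1ccc(Cl)cc1`: -57%

Compound 1 stands highest of the three in this assay, which here means the weakest effect. Compound 4 `Nc1scc(CN2CCN(c3cccc(C(F)(F)F)c3)CC2)c1C(=O)c1ccc(Cl)cc1` has not yet been measured. It differs from compound 1 in one place: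

3-(trifluoromethyl)phenyl in place of isopropyl on an amine nitrogen in a ring

Within the data shown here, two measured steps bear directly on this change, since each of them also replaces the isopropyl on the ring nitrogen with an aromatic ring. The step of a number 64.3 percentage points lower from compound 1 to compound 2 (beyond the scatter) and the step of a number 64.3 percentage points lower from compound 1 to compound 3 (beyond the scatter) were both large and both downward. Between the two aromatic variants themselves there was no change at the digits printed from compound 2 to compound 3 (within the scatter), so the kind of substituted phenyl made no difference within the scatter. A large downward step is therefore expected here as well, with compound 4 estimated at a number 57.3 percentage points lower from compound 1 to compound 4 (beyond the scatter) from compound 1. Compound 4 is expected to give a read-out near -50%, with a likely range from -75% to -20%, because both compound 2 at -57% and compound 3 at -57% landed in that region.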

Compound 4, a percentage reported as activity, at one concentration (the size of the read-out at that concentration, not a potency): -72%
Beside the measured number, compound 4's estimate is 22 percentage points above it, and the stated range covers the measured number.
By their numbers in this assay, from the lowest: compound 4; then compounds 2 and 3 (each within the scatter of the next); then compound 1.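

In this assay, the step of a number 79.3 percentage points lower from compound 1 to compound 4 (beyond the scatter) adds a third aromatic group on the amine nitrogen in the ring, and like the other two it sits far below the isopropyl of compound 1, where a lower number means a stronger effect. The new information is that the choice of substituted phenyl can matter at this position: compounds 2 and 3 could not be told apart, yet 3-(trifluoromethyl)phenyl gives a number 15 percentage points lower from compound 3 to compound 4 (beyond the scatter) and a number 15 percentage points lower from compound 2 to compound 4 (beyond the scatter), both modest steps but beyond the scatter, which leaves compound 4 lowest of the four. Nothing available explains why this group gives a lower number than the two halogen-bearing phenyl groups.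

The three phenyl groups differ both in which substituents they carry and in where these sit, so the compounds shown cannot separate those two changes. Also open, going by these compounds, is how a plain phenyl, a benzyl or a phenyl bearing a methoxy group on the same nitrogen would read in this assay, and whether the trifluoromethyl group itself accounts for the extra step.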